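Notes on the carbonyl substituent of the piperidine series

The source may report more compounds than this note shows. Statements on the series, on what has been measured and on what is new or still open speak of the compounds shown alone.

Measured so far:
Compound 1 `Cc1nc(S(C)(=O)=O)ccc1Oc1ncnc(OC2CCN(C(=O)OC(C)(C)CF)CC2)c1F`: in a functional assay on isolated protein for inhibition of Glucose-dependent insulinotropic receptor (Homo sapiens), read by HTRF and cAMP accumulation (on this read-out higher numbers stand for an effect only at larger amounts of compound and lower numbers for an effect already at smaller amounts), compound 1 gives 19.9 nM.
Compound 2 `CCC1(OC(=O)N2CCC(Oc3ncnc(Oc4ccc(S(C)(=O)=O)nc4C)c3F)CC2)CC1`: in this assay compound 2 gives 22 nM.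
Compound 3 `Cc1nc(S(C)(=O)=O)ccc1Oc1ncnc(OC2CCN(C(=O)SC3(C)CC3)CC2)c1F`: in this assay compound 3 gives 13.2 nM.

Compound 3 has the lowest of the three numbers, but the steps of a 1.5-fold lower number from compound 1 to compound 3 (0.18 log units; within the scatter) and a 1.7-fold lower number from compound 2 to compound 3 (0.22 log units; within the scatter) both lie within the scatter, as does a 1.1-fold higher number from compound 1 to compound 2 (0.04 log units; within the scatter), so no order among the three can be claimed.

Compound 4 `CCc1cnc(C(=O)N2CCC(Oc3ncnc(Oc4ccc(S(C)(=O)=O)nc4C)c3F)CC2)nc1` is the next case. Relative to compound 3 the change is a group of 8 heavy atoms (6 carbon, 2 nitrogen; one six-membered aromatic ring with 2 hetero atoms) in place of a group of 5 heavy atoms (4 carbon, 1 sulfur; one three-membered non-aromatic ring of carbon only), on a carbonyl carbon.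

All three measured steps concern the group on that same carbonyl carbon, and all are within the scatter. None of them, however, exchanges a saturated group for an aromatic ring, so they bear only indirectly on compound 4: they show that the shared core tolerates variation at this carbonyl carbon without a step beyond the scatter, and nothing more. On this basis the step of a 1.5-fold higher number from compound 3 to compound 4 (0.18 log units; within the scatter) is expected to be small, with no direction that can be called, and the range must be wider than for the measured steps.

For compound 4 in this assay the expected value is 20 nM, estimated to fall between 6 nM and 70 nM.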

Compound 4, half-maximal effective concentration: 4.7 nM
Estimate against measurement, compound 4: 4.3-fold (0.63 log units) above; measured number outside the range, below it.
By their numbers in this assay, from the lowest: compound 4; then compounds 3, 1 and 2 (each within the scatter of the next).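

In this assay, within the data shown here, the 5-ethylpyrimidin-2-yl group on the carbonyl carbon gives the first steps at this position that lie beyond the scatter (a 2.8-fold lower number from compound 3 to compound 4 (0.45 log units; beyond the scatter); a 4.2-fold lower number from compound 1 to compound 4 (0.63 log units; beyond the scatter); a 4.7-fold lower number from compound 2 to compound 4 (0.67 log units; beyond the scatter)), all of modest size. Compound 4 therefore has the lowest number of the four, while compounds 1, 2 and 3 stay within the scatter of each other, whether oxygen or sulfur joins their saturated groups to the carbonyl carbon, so this position is not as flat as those three alone suggested. Nothing available here gives a reason for this difference.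

Each of these steps exchanges the whole group, so the aromatic ring, its two ring nitrogens, the ethyl chain and the loss of the oxygen or sulfur link all change at once and cannot be separated. The compounds shown leave open how a pyrimidin-2-yl ring without the ethyl chain, a 5-propylpyrimidin-2-yl group or a plain phenyl ring on the same carbonyl carbon would read.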